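Extending the Aryl Ether of Compound 3 Toward Compound 4

This account rests on a few compounds, and the source may have more. Where it says the series, first, only, none or still open, it means among the compounds named here.

Measured so far:
compound 1, `CC(C)CCNc1nc(N)nc2ccccc12`: 2.11 uM
compound 2, `CCCCNc1nc(N)nc2cc(OC)ccc12`: 0.3 uM
compound 3, `CCCCNc1nc(N)nc2cccc(OC)c12`: 0.1 uM

In an ADME assay on HEK293 cells for agonist activity at Toll-like receptor 8 (Homo sapiens), read by a luciferase reporter, with a stated time of 6 h (on this read-out higher numbers stand for an effect only at larger amounts of compound and lower numbers for an effect already at smaller amounts), compound 3 gives the lowest of the three numbers. Its nearest neighbour is compound 2, whose number lies higher by a gap beyond the scatter, and the furthest is compound 1, whose number lies higher still, also beyond the scatter. Compound 3 therefore stands apart from both on this read-out.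

Compound 4, `CCCCNc1nc(N)nc2cccc(OCCOC)c12`, has not yet been measured in this assay. Compared with compound 3 the change is methoxymethyl in place of hydrogen on a saturated chain carbon bound to an oxygen on an aromatic ring. Said one bond further out, a methyl becomes a 2-methoxyethyl, or the methoxy becomes a 2-methoxyethoxy; the aryl ether itself stays where it is.

Going by the values given here, no step between measured compounds touches this part of the molecule, so there is no precedent. Compound 4 is expected to stay close to compound 3, with a small upward drift in this assay that may not clear the scatter, as a 2.0-fold higher number from compound 3 to compound 4 (0.30 log units; within the scatter). Compound 4 is estimated at 0.2 uM, within a range from 0.05 uM to 0.8 uM.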

Compound 4, minimum effective concentration: 0.2 uM
Estimate against measurement, compound 4: no gap at the digits printed; the range from low to high includes it.
By their numbers in this assay, from the lowest: compounds 3, 4 and 2 (each within the scatter of the next, the first and the last beyond it); then compound 1.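

In this assay, going by these compounds alone, the step of a 2.0-fold higher number from compound 3 to compound 4 (0.30 log units; within the scatter) is the first reading on this part of the molecule, and it shows that the methoxy can become a 2-methoxyethoxy without a difference that clears the scatter. The methoxymethyl brings 3 heavy atoms and 1 hydrogen-bond acceptor to a saturated chain carbon bound to an oxygen on an aromatic ring, yet this read-out does not separate compound 4 from compound 3. Nothing at hand bears on the reason for this result.

As far as these compounds go, whether the same holds for a longer chain, or for a chain ending in an amine or a carboxylic acid in place of the terminal methoxy, remains open. Equally open, from the compounds shown here alone, is whether the same change, made to the methoxy of compound 2, would read alike.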